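Aminophenyl to dichlorophenyl on a pyrazole-linked enone

This account rests on a few compounds, and the source may have more. Where it says the series, first, only, none or still open, it means among the compounds named here.

Measured compounds:
- compound 1, `COc1ccc(-c2cc(/C=C/C(=O)c3ccc(N)cc3)[nH]n2)cc1`, 1320 nM
- compound 2, `COc1cc(-c2cc(/C=C/C(=O)c3ccc(N)cc3)[nH]n2)cc(OC)c1OC`, "not determined" (no result reported)

In a functional assay on CAKI-1 cells (Homo sapiens) for inhibition, read by sulforhodamine B assay, with a stated time of 48 h (a lower number here means a stronger inhibitor of growth, a higher number a weaker inhibitor of growth), compound 1 gives 1320 nM. Compound 2 shares the enone and the same 4-aminophenyl on the carbonyl carbon but carries a different aryl ring on the other end of the shared core; for compound 2 the entry in this assay reads "not determined" (no result reported), so where it stands cannot be read from the data.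

Compound 3, `COc1cc(-c2cc(/C=C/C(=O)c3ccc(Cl)c(Cl)c3)[nH]n2)cc(OC)c1OC`, is the next compound in this account and has not been measured. It differs from compound 2 by 3,4-dichlorophenyl in place of 4-aminophenyl on a carbonyl carbon. Within the data shown here, no step between measured compounds covers this exchange, and compound 2 itself has no value, so the size and direction of the step cannot be read from any measured pair. Among the measured compounds shown here, the only anchor is compound 1, and the two changes separating it from compound 3 are both unquantified.

With that in mind, compound 3 is expected to give about 2500 nM in this assay, with a wide range from 300 nM to 20000 nM.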

Compound 3, concentration for 50% growth inhibition: 16900 nM
Compound 3: middle estimate off by 6.8-fold (0.83 log units), on the low side, within the range that was stated.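

In this assay compound 3 gives 16900 nM, but compound 2 has no single number there, so no step can be read between compound 2 and compound 3. No available evidence bears on this result. The compounds shown leave open how exchanging 4-aminophenyl for 3,4-dichlorophenyl on the carbonyl carbon alters growth inhibition, in direction or size.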